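The compounds below may be only part of what the source reports. "The series", "measured", "known", "first", "only" and "open" are said of these compounds alone.

Compound 1, `CSc1ccc(/C=C(\C(=O)c2ccc(Br)cc2)S(=O)(=O)c2ccc(C)cc2)cc1`, stands as the lowest of the three numbers recorded so far: in a functional assay on DU-145 cells (Homo sapiens) for inhibition, read by trypan blue exclusion, with a stated time of 96 h (on this read-out higher numbers stand for weaker inhibition of growth and lower numbers for stronger inhibition of growth), compound 1 gives 1000 nM. Its nearest neighbour is compound 2, `CSc1ccc(/C=C(\C(=O)c2ccc(Br)cc2)S(=O)(=O)Cc2ccc(C)cc2)cc1`, which gives 10000 nM, a change of a 10-fold higher number from compound 1 to compound 2 (1.00 log units; beyond the scatter). Compound 3, `CSc1ccc(/C=C(\C(=O)c2ccc(Br)cc2)S(=O)(=O)Cc2ccc(F)cc2)cc1`, gives 50000 nM, the step being a 50-fold higher number from compound 1 to compound 3 (1.70 log units; beyond the scatter); from compound 2 to compound 3 the step is a 5.0-fold higher number from compound 2 to compound 3 (0.70 log units; beyond the scatter). Compound 4, `Cc1ccc(S(=O)(=O)/C(=C/c2c[nH]c3ccccc23)C(=O)c2ccc(Br)cc2)cc1`, differs from compound 1 by 1H-indol-3-yl in place of 4-(methylsulfanyl)phenyl on a double-bonded chain carbon bound to a double-bonded chain carbon. Going by the values given here, the three measured steps all concern the group on the sulfonyl sulfur, so none bears on this change, and the expectation rests on no direct precedent. Compound 4 is therefore expected to sit near compound 1, with the step of a 1.5-fold higher number from compound 1 to compound 4 (0.18 log units; within the scatter) carrying wide uncertainty. The estimate for compound 4 is 1500 nM, within 200 nM to 12000 nM.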

Compound 4, concentration for 50% growth inhibition: 10000 nM
Estimate against measurement, compound 4: 6.7-fold (0.82 log units) below, within the range that was stated.
By their numbers in this assay, from the lowest: compound 1; then compounds 2 and 4 (each within the scatter of the next); then compound 3.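

In this assay, 1H-indol-3-yl in place of 4-(methylsulfanyl)phenyl gives a 10-fold higher number from compound 1 to compound 4 (1.00 log units; beyond the scatter) and so weakens growth inhibition beyond the scatter. This shows that the group on the double-bonded chain carbon matters as well as the group on the sulfonyl sulfur, the only place varied earlier. Nothing at hand accounts for this step. The compounds shown leave open whether the weakening follows from the added ring or the ring hydrogen on nitrogen, and whether a 4-methoxyphenyl or 4-aminophenyl group at this place would retain the inhibition seen with compound 1.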